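The source may report more compounds than this note shows. Statements on the series, on what has been measured and on what is new or still open speak of the compounds shown alone.

In a functional assay on HCT-116 cells (Homo sapiens) for inhibition, read by fluorescence, with a stated time of 48 h (a higher number here means a weaker inhibitor of growth, a lower number a stronger inhibitor of growth), compound 1 (`CC(C)(CO)COC1(c2ccc(Cl)cc2)c2ccccc2C(=O)N1Cc1ccccc1`) gives 71000 nM, compound 2 (`CC(=O)OCCCOC1(c2ccc(Cl)cc2)c2ccccc2C(=O)N1Cc1ccc(Cl)cc1`) gives 46000 nM and compound 3 (`CC(C)(CO)COC1(c2ccc(Cl)cc2)c2ccccc2C(=O)N1Cc1ccc(Cl)cc1`) gives 50000 nM. These values lie within the scatter of one another, so compound 1 holds no separate place among them. Compound 4 (`CC(C)[C@H](N)C(=O)OCC(C)(C)COC1(c2ccc(Cl)cc2)c2ccccc2C(=O)N1Cc1ccccc1`) differs from compound 1 by (1-amino-2-methylpropyl)carbonyl in place of hydrogen on an oxygen on a saturated carbon, which reads as hydroxy to ((1-amino-2-methylpropyl)carbonyl)oxy. For the measured compounds named here, two measured steps bear on this only indirectly. One is a 1.1-fold higher number from compound 2 to compound 3 (0.04 log units; within the scatter), a change of the chain on the same oxygen-linked side, and the other is a 1.4-fold lower number from compound 1 to compound 3 (0.15 log units; within the scatter), an aromatic chloro change. Both stay within the scatter, and neither tests this group, so no step beyond the scatter is expected in this assay. The expected size is a 1.4-fold lower number from compound 1 to compound 4 (0.15 log units; within the scatter). For compound 4 the estimated value is 50000 nM, with an expected range of 18000 nM to 100000 nM.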

Compound 4, concentration for 50% growth inhibition: 20000 nM
Compound 4: middle estimate off by 2.5-fold (0.40 log units), on the high side; the measured number falls inside the stated range.
By their numbers in this assay, from the lowest: compound 4; then compounds 2, 3 and 1 (each within the scatter of the next).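

In this assay, for the compounds shown here, the (1-amino-2-methylpropyl)carbonyl on the oxygen of compound 1 gives a 3.6-fold lower number from compound 1 to compound 4 (0.55 log units; beyond the scatter) and so the first step beyond the scatter; the earlier chain and chloro changes stayed within it. This oxygen is therefore a place where a change can move the number, though only modestly. No measurement at hand accounts for the step.

The compounds shown leave open whether the step needs the amine, which a 2-methylpropanoyl group, the same carbonyl chain without it, would test. As far as these compounds go, whether the gain carries over to compound 3 also remains open.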